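Adding a carbonyl to the side chain of compound 2

A few compounds are considered here, and "the series" means these few. Any claim that something is new, unique, unknown or untested is made for them only; others in the source may bear on it.

Compound 2 `CN1CCCN(CCCOc2cc(C(=O)N3CCCCc4sccc43)ccc2NC(=O)c2ccccc2-c2ccccc2)CC1` gives 2 nM in an assay on CHO cells for inhibition of Vasopressin V2 receptor (Homo sapiens), read by radioligand binding (on this read-out lower numbers stand for stronger inhibition and higher numbers for weaker inhibition), the highest of the two numbers recorded, and its nearest neighbour is compound 1 `CN1CCN(CCCCOc2cc(C(=O)N3CCCCc4sccc43)ccc2NC(=O)c2ccccc2-c2ccccc2)CC1`, which gives 1 nM. The step of a 2.0-fold higher number from compound 1 to compound 2 (0.30 log units; within the scatter) shows that reshaping the amine end of the chain barely moved the read-out. Compound 3 `CN1CCCN(C(=O)CCCOc2cc(C(=O)N3CCCCc4sccc43)ccc2NC(=O)c2ccccc2-c2ccccc2)CC1` differs from compound 2 by (4-methyl-1,4-diazepan-1-yl)carbonyl in place of 4-methyl-1,4-diazepan-1-yl on a saturated chain carbon, three bonds along the chain from an oxygen on an aromatic ring. Within the data shown here, no measured step shows a carbonyl entering this chain; the only comparison available, a 2.0-fold higher number from compound 1 to compound 2 (0.30 log units; within the scatter), concerns the ring alone and was small, so it gives little guidance. The change inserts a carbonyl and lengthens the chain by one atom, which is a larger alteration than the one recorded. A modest weakening is therefore expected, with compound 3 estimated at 5 nM in this assay, within a range from 1.5 nM to 20 nM, corresponding to an expected step of a 2.5-fold higher number from compound 2 to compound 3 (0.40 log units; beyond the scatter).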

Compound 3, half-maximal inhibitory concentration: 10 nM
Estimate against measurement, compound 3: 2.0-fold (0.30 log units) below; measured number inside the range.
By their numbers in this assay, from the lowest: compounds 1 and 2 (each within the scatter of the next); then compound 3.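

Inserting a carbonyl on this chain carbon gives a 5.0-fold higher number from compound 2 to compound 3 (0.70 log units; beyond the scatter) in this assay, a modest loss that, unlike the reshaping of the amine ring, lies beyond the scatter. Compound 3 sits further from compound 1, with a 10-fold higher number from compound 1 to compound 3 (1.00 log units; beyond the scatter) as another modest step, so this place accepts the (4-methyl-1,4-diazepan-1-yl)carbonyl group but at a measurable cost. Nothing measured here explains why the number rises.

The change adds a carbonyl and lengthens the chain in one move, so the two contributions remain unseparated; (4-methyl-1,4-diazepan-1-yl)methyl at this place would pull them apart by giving the longer chain without the carbonyl. Going by these compounds, whether the cost carries over to other amines is also open, and (4-methylpiperazin-1-yl)carbonyl at this place would test that.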